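The compounds below may be only part of what the source reports. "The series", "measured", "known", "first", "only" and "open" are said of these compounds alone.

Measured so far:
- compound 1 `O=C(NNc1ccccc1Cl)c1cccc(NS(=O)(=O)c2cnc(O)nc2O)c1`: 1460 nM
- compound 2 `O=C(NNc1cccc(Cl)c1)c1cccc(NS(=O)(=O)c2cnc(O)nc2O)c1`: 6640 nM
- compound 3 `O=C(NNc1ccccc1Cl)c1ccccc1NS(=O)(=O)c1cnc(O)nc1O`: 5480 nM

All three were read in a functional assay on A549 cells (Homo sapiens) for antiproliferative activity, read by MTT assay, with a stated time of 24 h; on this read-out higher numbers stand for weaker inhibition and lower numbers for stronger inhibition. Compound 1 and compound 2 share a core and differ by 3-chlorophenyl in place of 2-chlorophenyl on an amine nitrogen; this change gave a 4.5-fold higher number from compound 1 to compound 2 (0.66 log units; beyond the scatter). Compound 3 carries a different core; the difference between the two cores is not broken down here. In this assay compound 3 gives 5480 nM, within the scatter of compound 2 and beyond it relative to compound 1.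

Compound 4 `O=C(NNc1cccc(Cl)c1)c1ccccc1NS(=O)(=O)c1cnc(O)nc1O` is not yet measured. It differs from compound 3 by 3-chlorophenyl in place of 2-chlorophenyl on an amine nitrogen, the same kind of change as from compound 1 to compound 2, and the place reads the same in both. For the measured compounds named here, because of a 4.5-fold higher number from compound 1 to compound 2 (0.66 log units; beyond the scatter) the expected step on the new core is a 3.3-fold higher number from compound 3 to compound 4 (0.52 log units; beyond the scatter), with wider uncertainty since only one precedent exists and the core of compound 3 differs. Compound 4 is estimated at 18000 nM, expected between 6000 nM and 55000 nM.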

Compound 4, half-maximal inhibitory concentration: 5290 nM
For compound 4 the middle estimate is 3.4-fold (0.53 log units) above the measured one; measured number below the stated range.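

In this assay, 3-chlorophenyl in place of 2-chlorophenyl on an amine nitrogen gave a 1.0-fold lower number from compound 3 to compound 4 (0.02 log units; within the scatter), so the step seen on the core of compound 1 did not carry over to the core of compound 3. The two steps do not agree: the same change on two cores in this assay, a 4.5-fold higher number (0.66 log units; beyond the scatter) from compound 1 to compound 2 and a 1.0-fold lower number (0.02 log units; within the scatter) from compound 3 to compound 4, 4.7-fold (0.67 log units) apart, beyond the scatter of two such steps. Within this series, the outcome of this change therefore depends on the core it is made on, so a step read on one core is not a safe guide to the other; the data do not show why, and a single pair on each core gives no rule for any further core.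

From the compounds shown here alone, it remains open whether a plain phenyl, a fluorophenyl or a methoxyphenyl on that amine nitrogen would give values that separate on the core of compound 1 and stay together on the core of compound 3. Also open, going by these compounds, is how the same chlorophenyl exchange would read on a core carrying a methyl or methoxy group on the central benzene ring.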